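Moving the Chlorine on the Chlorophenyl Group

A few compounds are considered here, and "the series" means these few. Any claim that something is new, unique, unknown or untested is made for them only; others in the source may bear on it.

Compound 1 `Fc1cccc(-c2nc(Nc3ccccc3F)c3cc(F)ccc3n2)c1` and compound 2 `Fc1cccc(-c2nc(Nc3ccc(Cl)cc3)c3cc(F)ccc3n2)c1` share one core and differ only in the group carried by a nitrogen on an aromatic ring. In a functional assay on COLO 205 cells (Homo sapiens) for cytotoxicity, read by MTT assay, with a stated time of 48 h (a lower number here means a stronger inhibitor, a higher number a weaker inhibitor), compound 1 gives > 50000 nM, which is a limit of the assay rather than a number. In this assay compound 2 gives 32600 nM. Within the data shown here, the step of an at least 1.5-fold lower number from compound 1 to compound 2 (0.18 log units; that floor lies within the scatter) is the single measured comparison, and its floor sits inside the scatter, as the limit of > 50000 nM in this assay, at which 1 of the 2 values shown sits, sets that floor. Among the measured compounds shown here, compound 2 is thus the one compound with a real number here, and it is a weak inhibitor.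

Compound 3 `Fc1cccc(-c2nc(Nc3cccc(Cl)c3)c3cc(F)ccc3n2)c1` differs from compound 2 in the same place: 3-chlorophenyl in place of 4-chlorophenyl on a nitrogen on an aromatic ring. For the measured compounds named here, no measured step moves a chlorine from one position to another on this ring, so the expectation rests only on compound 2 and on the modest size of an at least 1.5-fold lower number from compound 1 to compound 2 (0.18 log units; that floor lies within the scatter). With that little to go on, the expected step of a 1.1-fold lower number from compound 2 to compound 3 (0.04 log units; within the scatter) is none beyond the scatter. Compound 3 is therefore estimated at 30000 nM, within a range from 12000 nM to 80000 nM in this assay.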

Compound 3, half-maximal inhibitory concentration: > 50000 nM
Compound 3 ended at the assay's limit; the forecaster's own chance of this, stated with the estimate: 30%; at least 1.6-fold (0.22 log units) between middle value and limit.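

This pair isolates the place of the chlorine on the ring carried by the nitrogen, and in this assay changing 4-chlorophenyl to 3-chlorophenyl gives an at least 1.5-fold higher number from compound 2 to compound 3 (0.18 log units; that floor lies within the scatter). Among these compounds, the move therefore shows no change that can be told apart from ordinary scatter, and its true size stays hidden because the value of compound 3 is a limit of the assay, not a number: the limit of > 50000 nM in this assay, at which 2 of the 3 values shown sit. The step from compound 1 to compound 3 cannot be read, since both values are limits, so compound 2 remains the only compound here with a real number.

Going by these compounds, it remains open whether a phenyl ring carrying a methoxy group, an amine or a carboxylic acid in place of the chlorine would give a number clearly lower than that of compound 2. On these data alone, it is equally open whether a longer chain on the nitrogen, in place of the phenyl ring, would bring any compound with this shared core well away from the limit.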